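This account rests on a few compounds, and the source may have more. Where it says the series, first, only, none or still open, it means among the compounds named here.

Measured so far:
- compound 1, `O=C(COc1cccc2ccccc12)N/N=C/c1ccc(O)cc1`: 60.6 ug/mL
- compound 2, `O=C(COc1cccc2ccccc12)N/N=C/c1c(O)ccc2ccccc12`: 1.94 ug/mL

In an ADME assay on HEL cells (Homo sapiens) for cytotoxicity (on this read-out lower numbers stand for higher toxicity in this test and higher numbers for lower toxicity in this test), compound 1 gives 60.6 ug/mL, the highest of the two numbers; compound 2 gives a much lower number in this assay, 1.94 ug/mL, a gap beyond the scatter. Compound 3, `O=C(COc1cccc2ccccc12)N/N=C/c1cccc(Br)c1`, has not yet been measured in this assay. It differs from compound 1 in one place: 3-bromophenyl in place of 4-hydroxyphenyl on a carbon with a double bond to nitrogen. Within the data shown here, no measured pair shows this exact change, so the direction rests on general expectation only. Among the measured compounds shown here, the one comparison available, compound 1 against compound 2, shows that altering the aryl group attached to the carbon with a double bond to nitrogen can move the number sharply downward. A moderate downward step is expected for a 2.0-fold lower number from compound 1 to compound 3 (0.31 log units; beyond the scatter), possibly beyond the scatter but less than the gap to compound 2. Compound 3 is estimated at 30 ug/mL in this assay, with a range of 8 ug/mL to 90 ug/mL.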

Compound 3, half-maximal cytotoxic concentration: 48.6 ug/mL
Beside the measured number, compound 3's estimate is 1.6-fold (0.21 log units) below it; the range from low to high includes it.
By their numbers in this assay, from the lowest: compound 2; then compounds 3 and 1 (each within the scatter of the next).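

In this assay replacing 4-hydroxyphenyl with 3-bromophenyl on a carbon with a double bond to nitrogen gives a 1.2-fold lower number from compound 1 to compound 3 (0.10 log units; within the scatter) and so leaves the read-out within the scatter. This position therefore accepts an aryl group with no hydrogen-bond donor or acceptor, and the low number of compound 2 at 1.94 ug/mL does not follow from every change of aryl group here. No measurement in hand explains why compound 1 and compound 3 read alike.

Still open, going by these compounds, is whether 3-hydroxyphenyl or 4-bromophenyl would read like compound 1, which would separate the identity of the substituent from its place on the ring. Also open, on these data alone, is how the number responds to an amine or a carboxylic acid on that ring.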